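The source may report more compounds than this note shows. Statements on the series, on what has been measured and on what is new or still open speak of the compounds shown alone.

Notes on the series. In a functional assay (aorta) with Rattus norvegicus as the target (on this read-out lower numbers stand for stronger inhibition and higher numbers for weaker inhibition), compound 1 `CCOC(=O)CN(c1ccc(F)cc1)[C@H]1c2cc(C#N)ccc2OC(C)(C)[C@@H]1O` gives only a limit, > 30000 nM. Compound 2 `CCOC(=O)CN(c1ccc(Cl)cc1)[C@H]1c2cc(C#N)ccc2OC(C)(C)[C@@H]1O` likewise stops at a limit, > 30000 nM. Compound 3 `CCOC(=O)CN(c1nc2ccccc2o1)[C@H]1c2cc(C#N)ccc2OC(C)(C)[C@@H]1O` also returns a limit, > 30000 nM. The three changes among them therefore carry no readable size: a step that the two limits leave unreadable from compound 1 to compound 2, a step that the two limits leave unreadable from compound 1 to compound 3 and a step that the two limits leave unreadable from compound 2 to compound 3. Where compound 1 stands cannot be placed on a scale; all that is known is the limit of > 30000 nM in this assay, at which 3 of the 3 values shown sit.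

Compound 4 `CC1(C)Oc2ccc(C#N)cc2[C@H](N(Cc2ncc[nH]2)c2ccc(F)cc2)[C@H]1O` differs from compound 1 by 1H-imidazol-2-yl in place of ethoxycarbonyl on a saturated chain carbon bound to a nitrogen on an aromatic ring. For the measured compounds named here, none of the measured steps touches the (ethoxycarbonyl)methyl arm; they vary only the group on the amine nitrogen, and each reads as a limit, so no measured step bears on this change in size or direction. The only anchor is that every member so far, compound 1 included, sits at the limit. On that basis compound 4 is expected to remain weak in this assay, with the expected step of an at least 1.5-fold lower number from compound 1 to compound 4 (0.17 log units; that floor lies within the scatter) more likely a modest gain than none, though the result may again be reported only as a limit. The estimate for compound 4 is 20000 nM, between 3000 nM and 60000 nM.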

Compound 4, half-maximal inhibitory concentration: > 30000 nM
Compound 4: only a limit was reported; the forecaster's own chance of this, stated with the estimate: 60%; at least 1.5-fold (0.17 log units) between middle value and limit.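

In this assay compound 4 stops at a limit, > 30000 nM. With compound 1 also only a limit, no step can be read between compound 1 and compound 4, and the series stays as it was: the limit of > 30000 nM in this assay, at which 4 of the 4 values shown sit.

The compounds shown leave open the size and direction of any of these changes, and whether any structure here gives a number rather than a limit.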